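Notes on an aryl swap in a thiosemicarbazone series

A few compounds are considered here, and "the series" means these few. Any claim that something is new, unique, unknown or untested is made for them only; others in the source may bear on it.

Compound 2 `CC1=CC[C@@H]([C@@](C)(O)CCCC(C)(C)NC(=S)N/N=C\c2ccc(O)cc2)CC1` sits at the limit of a functional assay on K562 cells (Homo sapiens) for cytotoxicity, read by sulforhodamine B assay; on this read-out higher numbers stand for lower toxicity in this test and lower numbers for higher toxicity in this test: in this assay compound 2 gives > 100000 nM, a limit rather than a number. Compound 1 `CC1=CC[C@@H]([C@@](C)(O)CCCC(C)(C)NC(=S)N/N=C\c2ccccc2)CC1` is at the same limit, giving > 100000 nM in this assay. Compound 3 `CC1=CC[C@@H]([C@@](C)(O)CCCC(C)(C)NC(=S)N/N=C\c2ccc([N+](=O)[O-])cc2)CC1` gives 45500 nM in this assay. Of the measured steps, an at least 2.1-fold lower number from compound 2 to compound 3 (0.34 log units; beyond the scatter) and an at least 2.1-fold lower number from compound 1 to compound 3 (0.34 log units; beyond the scatter), whereas a step that the two limits leave unreadable from compound 1 to compound 2. The shared limit of > 100000 nM in this assay, at which 2 of the 3 values shown sit, leaves compound 1 and compound 2 unresolved against each other. The change to compound 4 `CC1=CC[C@@H]([C@@](C)(O)CCCC(C)(C)NC(=S)N/N=C\c2ccccc2Cl)CC1` is 2-chlorophenyl in place of 4-hydroxyphenyl on a carbon with a double bond to nitrogen. Among the measured compounds shown here, no measured step exchanges a hydroxy for a chloro, so the nitro step stands only as a loose bound. Compound 4 is expected to stay at or near the limit, estimated at 100000 nM within 40000 nM to 300000 nM. The expected step of a number no higher from compound 2 to compound 4 (the limit leaves the size open) is thus small.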

Compound 4, concentration lethal to 50% of the cells: 8500 nM
For compound 4 the middle estimate is 12-fold (1.07 log units) above the measured one; the measured number lies below the stated range.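

In this assay, the aryl group on the carbon with a double bond to nitrogen can move the read-out much further than the nitro step suggested: 2-chlorophenyl gives an at least 11-fold lower number from compound 2 to compound 4 (1.07 log units; beyond the scatter), and chloro in place of hydrogen gives an at least 11-fold lower number from compound 1 to compound 4 (1.07 log units; beyond the scatter). Even against 4-nitrophenyl, the other group that leaves the limit, 2-chlorophenyl gives a 5.4-fold lower number from compound 3 to compound 4 (0.73 log units; beyond the scatter). The two larger steps are bounds only: the limit of > 100000 nM in this assay, at which 2 of the 4 values shown sit.

On these data alone, whether a bromo, a methoxy or an amine on the aromatic ring would follow chloro stays open. So does whether the place of the chloro on the ring matters.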